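The source may report more compounds than this note shows. Statements on the series, on what has been measured and on what is new or still open speak of the compounds shown alone.

Of the compounds shown here, two of one shared core have been measured for how tightly they bind, and a third awaits its number. Compound 1 `COc1cc2nc(N3CCN(C(=O)Nc4ccccc4)CC3)nc(N)c2cc1OC` carries a phenylcarbamoyl group on an amine nitrogen in a ring; in an assay for binding affinity to Adrenergic receptor alpha-1 (Rattus norvegicus) (on this read-out higher numbers stand for weaker inhibition and lower numbers for stronger inhibition), compound 1 gives 27.5 nM. Compound 2 `COc1cc2nc(N3CCN(S(=O)(=O)c4ccc(C)cc4)CC3)nc(N)c2cc1OC` carries a (4-methylphenyl)sulfonyl group in the same place, and in this assay compound 2 gives 11.5 nM. Among the compounds with values here, the only measured step between them is a 2.4-fold lower number from compound 1 to compound 2 (0.38 log units; beyond the scatter), which puts compound 2 at the lower of the two numbers, with compound 1 as its only neighbour. Compound 3 `COc1cc2nc(N3CCN(S(=O)(=O)c4cccs4)CC3)nc(N)c2cc1OC` differs from compound 2 by thiophen-2-yl in place of 4-methylphenyl on a sulfonyl sulfur. Within the data shown here, no measured step bears directly on this change, since the one step seen swaps the whole group on the ring nitrogen rather than the ring on the sulfonyl sulfur. With nothing pointing one way or the other, the expectation for compound 3 is a step of a 1.0-fold higher number from compound 2 to compound 3 (0.02 log units; within the scatter), that is, no movement beyond the scatter. Compound 3 is therefore estimated at 12 nM, with a range from 4 nM to 36 nM.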

Compound 3, half-maximal inhibitory concentration: 33.9 nM
Estimate against measurement, compound 3: 2.8-fold (0.45 log units) below; the measured number falls inside the stated range.
By their numbers in this assay, from the lowest: compound 2; then compounds 1 and 3 (each within the scatter of the next).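

In this assay the ring on the sulfonyl sulfur proves to count in its own right, and not only the whole group on the ring nitrogen: thiophen-2-yl in place of 4-methylphenyl gives a clear move (a 2.9-fold higher number from compound 2 to compound 3 (0.47 log units; beyond the scatter)). The sulfonyl link alone therefore does not carry the low number of compound 2, since (thiophen-2-yl)sulfonyl in place of phenylcarbamoyl leaves the two compounds indistinguishable in this read-out (a 1.2-fold higher number from compound 1 to compound 3 (0.09 log units; within the scatter)). No measured property of either ring is available to account for the move from 4-methylphenyl to thiophen-2-yl.

This one swap changes several things at once, including ring size, the ring sulfur and the methyl group, so the compounds shown cannot say which of these matters. A plain phenyl ring on the sulfonyl sulfur would separate the methyl group from the ring change, while thiophen-3-yl or a short alkyl chain such as ethyl would show whether the placing of the ring sulfur, or an aromatic ring at all, makes a difference here.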